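The source may report more compounds than this note shows. Statements on the series, on what has been measured and on what is new or still open speak of the compounds shown alone.

Working notes on the series.

Compound 1 `CCCCCCCCCCCCC#Cc1cn([C@H]2CC[C@@H](CO)O2)c(=O)[nH]c1=O` is the reference point. In an ADME assay on Vero cells (Homo sapiens) for cytotoxicity against Vero (Chlorocebus sabaeus), read by MTT assay (on this read-out higher numbers stand for lower toxicity in this test and lower numbers for higher toxicity in this test), compound 1 gives > 100 ug/mL, which is a limit of the test and not a number. Compound 3 `CCCCCCCCC#Cc1cn([C@H]2CC[C@@H](CO)O2)c(=O)[nH]c1=O` shares the core and in this assay gives > 100 ug/mL, again a limit. Compound 2 `CCCCCCCCC#Cc1cn([C@H]2C[C@H](F)[C@@H](CO)O2)c(=O)[nH]c1=O` in this assay gives > 100 ug/mL, also a limit. Because every value sits at the limit of > 100 ug/mL in this assay, at which 3 of the 3 values shown sit, the two measured steps stay unreadable: a step that the two limits leave unreadable from compound 1 to compound 3 and a step that the two limits leave unreadable from compound 2 to compound 3.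

The change to compound 4 `CCCCCCCCCCCCC#Cc1cn(C2CC(F)C(CO)O2)c(=O)[nH]c1=O` is 4-fluoro-5-(hydroxymethyl)oxolan-2-yl in place of 5-(hydroxymethyl)oxolan-2-yl on an aromatic nitrogen. Among the compounds with values here, it is the same kind of change as the one from compound 3 to compound 2, whose two values show only the shared limit and neither a rise nor a fall in toxicity.

Nothing measured points to a readable shift, so the expectation for the step from compound 1 to compound 4 is a number no higher from compound 1 to compound 4 (the limit leaves the size open), that is, none beyond the scatter and most likely another limit. Compound 4 is therefore estimated at 100 ug/mL in this assay, with a range from 50 ug/mL to 200 ug/mL.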

Compound 4, half-maximal cytotoxic concentration: > 100 ug/mL
Compound 4 ended at the assay's limit (the forecaster's own chance of this, stated with the estimate: 85%); the middle value sits exactly at the limit.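

The step between compound 1 and compound 4 cannot be read, and no new comparison follows from compound 4, because the result is a limit of the test and not a number: the limit of > 100 ug/mL in this assay, at which 4 of the 4 values shown sit.

The compounds shown leave open how toxic any of them is in this assay and whether 4-fluoro-5-(hydroxymethyl)oxolan-2-yl in place of 5-(hydroxymethyl)oxolan-2-yl changes that toxicity at all.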